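Replacing a Carboxypyrrolidine with an Acetamidoethylamine

The source may hold more compounds than are shown below. What is called first, only, known or untested is meant among the compounds shown, and "the series" means these compounds.

Measured compounds:
Compound 1 `COc1ccc(/C=C\c2cc(OC)c(OC)c(OC)c2)cc1OCc1ccc(CN2CC[C@H](C(=O)O)C2)cc1`: > 10000 nM
Compound 2 `COc1ccc(/C=C\c2cc(OC)c(OC)c(OC)c2)cc1OCc1ccc(CN[C@H](C(=O)O)[C@@H](C)O)cc1`: > 10000 nM
Compound 3 `COc1ccc(/C=C\c2cc(OC)c(OC)c(OC)c2)cc1OCc1ccc(CNCCO)cc1`: 1200 nM

In a functional assay on MC-38 cells (Mus musculus) for antiproliferative activity, read by CCK-8 assay, with a stated time of 48 h (a higher number here means a weaker inhibitor, a lower number a stronger inhibitor), compound 1 gives > 10000 nM, which is a limit of the assay rather than a number. Compound 2 likewise gives > 10000 nM, also a limit. Compound 3 gives 1200 nM. The step that the two limits leave unreadable from compound 1 to compound 2 therefore cannot be read, because both values sit at the limit of > 10000 nM in this assay, at which 2 of the 3 values shown sit. The steps of an at least 8.3-fold lower number from compound 1 to compound 3 (0.92 log units; beyond the scatter) and an at least 8.3-fold lower number from compound 2 to compound 3 (0.92 log units; beyond the scatter) both run toward the compound without a carboxylic acid.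

Compound 4 `COc1ccc(/C=C\c2cc(OC)c(OC)c(OC)c2)cc1OCc1ccc(CNCCNC(C)=O)cc1` has not yet been measured in this assay. It differs from compound 1 as follows: (2-acetamidoethyl)amino in place of 3-carboxypyrrolidin-1-yl on a saturated chain carbon bound to an aromatic carbon. Like compound 3, compound 4 carries no carboxylic acid on the amine chain, so the step from compound 1 to compound 3 is the closest guide. Compound 4 is expected to move in the same direction, with an estimated step of an at least 6.6-fold lower number from compound 1 to compound 4 (0.82 log units; beyond the scatter). Compound 4 is thus estimated at 1500 nM, with a range from 500 nM to 6000 nM.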

Compound 4, half-maximal inhibitory concentration: 1800 nM
For compound 4 the middle estimate is 1.2-fold (0.08 log units) below the measured one, and the stated range covers the measured number.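

In this assay, a second amine chain without a carboxylic acid separates from both acid-bearing compounds, with an at least 5.5-fold lower number from compound 1 to compound 4 (0.74 log units; beyond the scatter) and an at least 5.5-fold lower number from compound 2 to compound 4 (0.74 log units; beyond the scatter). The size of these two steps is only a bound, because compound 1 and compound 2 each stand at a limit of the assay: the limit of > 10000 nM in this assay, at which 2 of the 4 values shown sit. Acetamido in place of hydroxy on the saturated chain carbon gives no readable difference, with a 1.5-fold higher number from compound 3 to compound 4 (0.18 log units; within the scatter), so these two groups cannot be told apart here.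

As far as these compounds go, whether a plain pyrrolidine, or a methyl ester in place of the carboxylic acid, would match compound 3 and compound 4 stays open. From the compounds shown here alone, it is also open how a longer chain carrying a primary amine would read in this assay.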